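A few compounds are considered here, and "the series" means these few. Any claim that something is new, unique, unknown or untested is made for them only; others in the source may bear on it.

In a functional assay on HL-60 cells (Homo sapiens) for antiproliferative activity, with a stated time of 72 h (on this read-out lower numbers stand for stronger inhibition and higher numbers for weaker inhibition), compound 1 (`OC[C@H]1O[C@@H](n2cnc3c(NCc4cccc(F)c4)ncnc32)[C@H](O)[C@@H]1O`) gives 920 nM, compound 2 (`COc1ccccc1CNc1ncnc2c1ncn2[C@@H]1O[C@H](CO)[C@@H](O)[C@H]1O`) gives 2300 nM, and compound 3 (`OC[C@H]1O[C@@H](n2cnc3c(NCc4ccc(Cl)cc4Cl)ncnc32)[C@H](O)[C@@H]1O`) stands highest of the three at 96300 nM. Compound 4 (`OC[C@H]1O[C@@H](n2cnc3c(NCc4ccc(F)cc4F)ncnc32)[C@H](O)[C@@H]1O`) is unmeasured and differs from compound 3 by 2,4-difluorophenyl in place of 2,4-dichlorophenyl on a saturated chain carbon bound to a nitrogen on an aromatic ring, with 2,4-difluorophenyl in place of 2,4-dichlorophenyl on a saturated chain carbon bound to a nitrogen on an aromatic ring. All three measured steps changed this same group: a 2.5-fold higher number from compound 1 to compound 2 (0.40 log units; beyond the scatter) was modest, while a 100-fold higher number from compound 1 to compound 3 (2.02 log units; beyond the scatter) and a 42-fold higher number from compound 2 to compound 3 (1.62 log units; beyond the scatter) were large. None of them swaps 2,4-dichlorophenyl for 2,4-difluorophenyl directly, but only compound 3 stands so high, and the fluorinated compound 1 gives 920 nM. A large fall is therefore expected, as a 32-fold lower number from compound 3 to compound 4 (1.51 log units; beyond the scatter). Compound 4 is estimated at 3000 nM, with an expected range of 500 nM to 30000 nM.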

Compound 4, half-maximal inhibitory concentration: 3400 nM
Beside the measured number, compound 4's estimate is 1.1-fold (0.05 log units) below it; the measured number falls inside the stated range.
By their numbers in this assay, from the lowest: compound 1; then compounds 2 and 4 (each within the scatter of the next); then compound 3.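

In this assay, the direct swap gives a 28-fold lower number from compound 3 to compound 4 (1.45 log units; beyond the scatter), so the very high number of compound 3 goes with the two chlorines and not with the 2,4-substituted phenyl as such. With fluorine in those places, the group stays near the others, with a 1.5-fold higher number from compound 2 to compound 4 (0.17 log units; within the scatter) and a 3.7-fold higher number from compound 1 to compound 4 (0.57 log units; beyond the scatter). Nothing given here explains why the chlorines and fluorines differ so sharply. From the compounds shown here alone, what remains open is whether a single chlorine on the phenyl ring is enough for the loss. A dibromophenyl or dimethylphenyl group would show whether it extends beyond the dichlorophenyl.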